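Aortic series: aryl substituent swap at the trifluoromethyl site

The source may report more compounds than this note shows. Statements on the series, on what has been measured and on what is new or still open speak of the compounds shown alone.

Measured compounds:
compound 1, `CCO/C(O)=C1\C(C)=NC(C)=C(C(=O)OCCCN2C(=O)c3ccccc3S2(=O)=O)C1c1ccccc1[N+](=O)[O-]`, 2.6 nM
compound 2, `CCO/C(O)=C1\C(C)=NC(C)=C(C(=O)OCCCN2C(=O)c3ccccc3S2(=O)=O)C1c1ccccc1C(F)(F)F`, 0.8 nM
compound 3, `CC1=NC(C)=C(C(=O)OCCCN2C(=O)c3ccccc3S2(=O)=O)C(c2ccccc2C(F)(F)F)/C1=C(\O)OC(C)C`, 2.7 nM

In a functional assay (aorta) with Oryctolagus cuniculus as the target (a higher number here means a weaker inhibitor, a lower number a stronger inhibitor), compound 2 gives the lowest of the three numbers; compound 1 sits a 3.3-fold lower number from compound 1 to compound 2 (0.51 log units; beyond the scatter) away and compound 3 a 3.4-fold higher number from compound 2 to compound 3 (0.53 log units; beyond the scatter) away, both beyond the scatter. Compound 4, `CCO/C(O)=C1\C(C)=NC(C)=C(C(=O)OCCCN2C(=O)c3ccccc3S2(=O)=O)C1c1ccccc1Cl`, differs from compound 2 by chloro in place of trifluoromethyl on an aromatic carbon. Going by the values given here, of the measured steps only the one from compound 1 to compound 2 touches this aromatic carbon, and it was modest: a 3.3-fold lower number from compound 1 to compound 2 (0.51 log units; beyond the scatter). The step from compound 2 to compound 3 concerns the ester and does not bear on it. Nothing measured tells how chloro compares with trifluoromethyl at this carbon, so the expected step is small, in either direction, and most likely a slight rise, since compound 2 already holds the lowest number. Compound 4 is therefore expected to come in near compound 2, estimated as a 1.9-fold higher number from compound 2 to compound 4 (0.27 log units; within the scatter). The estimate for compound 4 in this assay is 1.5 nM, with a range from 0.5 nM to 5 nM.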

Compound 4, half-maximal inhibitory concentration: 3.9 nM
Compound 4: the middle estimate sits 2.6-fold (0.41 log units) below what was measured; measured number inside the range.
By their numbers in this assay, from the lowest: compound 2; then compounds 1, 3 and 4 (each within the scatter of the next).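

In this assay the change from trifluoromethyl to chloro on this aromatic carbon gives a 4.9-fold higher number from compound 2 to compound 4 (0.69 log units; beyond the scatter) and shows that trifluoromethyl is not simply interchangeable with a halogen here. Chloro and nitro do not separate, with a 1.5-fold higher number from compound 1 to compound 4 (0.18 log units; within the scatter) as the reading, so among the three groups tried at this carbon only trifluoromethyl stands apart, and this rests on compound 1, compound 2 and compound 4 alone. Nothing at hand accounts for trifluoromethyl standing apart from chloro and nitro.

Open, as far as these compounds go, is whether a methoxy group, a fluoro group or an amine on this carbon would match compound 2 or fall with compound 1 and compound 4. Also open, from the compounds shown here alone, is whether the ester change seen with trifluoromethyl would carry over to the chloro compound.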